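This account rests on a few compounds, and the source may have more. Where it says the series, first, only, none or still open, it means among the compounds named here.

Measured so far:
compound 1, `Cc1ccc(OCC2CC2)cc1-c1cccc(COc2ccc(OCC(=O)O)c(F)c2)c1`, in a functional assay on CHO cells for agonist activity at Free fatty acid receptor 1 (Homo sapiens), read by FLIPR and calcium flux (a higher number here means that more compound is needed for the effect, a lower number that less compound is needed), compound 1 gives 340 nM;
compound 2, `COc1cccc(-c2cccc(COc3ccc(OCC(=O)O)c(F)c3)c2)c1`, in this assay compound 2 gives 540 nM.

Compound 2 stands level with compound 1; the gap between the two numbers is within the scatter of this assay. The step to compound 3, `O=C(O)COc1ccc(OCc2cccc(-c3cccc(OCC4CC4)c3)c2)cc1F`, is cyclopropyl in place of hydrogen on a saturated chain carbon bound to an oxygen on an aromatic ring. Among the measured compounds shown here, no measured pair shows this change on its own, so no step size is known. Compound 1 carries the same cyclopropylmethoxy group on its other ring and is within the scatter of compound 2, so for compound 3 the expected step of a 1.4-fold lower number from compound 2 to compound 3 (0.15 log units; within the scatter) is small, toward a lower number at most. Compound 3 is estimated at 380 nM, range 150 nM to 1000 nM.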

Compound 3, half-maximal effective concentration: 670 nM
Compound 3: the middle estimate sits 1.8-fold (0.25 log units) below what was measured, within the range that was stated.
By their numbers in this assay, from the lowest: compounds 1, 2 and 3 (each within the scatter of the next).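

In this assay, cyclopropyl in place of hydrogen on a saturated chain carbon bound to an oxygen on an aromatic ring gives a 1.2-fold higher number from compound 2 to compound 3 (0.09 log units; within the scatter), so methoxy and cyclopropylmethoxy read alike at this place. Hydrogen in place of methyl on an aromatic carbon gives a 2.0-fold higher number from compound 1 to compound 3 (0.29 log units; within the scatter), so this second change also stays inside the scatter. Nothing at hand explains either step.
Open, from the compounds shown here alone, is whether a longer chain on that oxygen, or an amine at its end, would move the number beyond the scatter. Also open, going by these compounds, is how the methyl on the aromatic carbon reads alongside methoxy.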